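Compound 1 to compound 4: removing the 4-chlorophenyl

The source may report more compounds than this note shows. Statements on the series, on what has been measured and on what is new or still open speak of the compounds shown alone.

Measured in an ADME assay on PBMC cells (Homo sapiens) for cytotoxicity, read by MTT assay, with a stated time of 24 h; a higher number here means a weaker inhibitor, a lower number a stronger inhibitor:
- compound 1 `COc1cc(C)cc2c1C(=O)C=C(c1c(C)cc3c(c1OC)C(=O)C(Nc1ccc(Cl)cc1)=CC3=O)C2=O`: 44900 nM
- compound 2 `COc1cc(C)cc2c1C(=O)C=C(c1c(C)cc3c(c1OC)C(=O)C(NCc1ccccc1)=CC3=O)C2=O`: > 100000 nM (a limit of the assay, not a number)
- compound 3 `CCOC(=O)CNC1=CC(=O)c2cc(C)c(C3=CC(=O)c4c(OC)cc(C)cc4C3=O)c(OC)c2C1=O`: 96200 nM

Compound 1, at 44900 nM, has the lower of the two actual numbers in this assay, and compound 3 is its nearest neighbour. Compound 2 stands at the limit of > 100000 nM in this assay, at which 1 of the 3 values shown sits.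

The next compound is compound 4 `COc1cc(C)cc2c1C(=O)C=C(c1c(C)cc3c(c1OC)C(=O)C(N)=CC3=O)C2=O`, not yet measured. The change is hydrogen in place of 4-chlorophenyl on an amine nitrogen.

Among the measured compounds shown here, two measured steps bear on it, as both replace the same 4-chlorophenyl on that nitrogen. The benzyl replacement gave an at least 2.2-fold higher number from compound 1 to compound 2 (0.34 log units; beyond the scatter). The (ethoxycarbonyl)methyl replacement gave a 2.1-fold higher number from compound 1 to compound 3 (0.33 log units; beyond the scatter). Both moved upward by a modest amount, although the first is only a floor. For the measured compounds named here, no measured compound carries the free amino group, so this is an extrapolation from these two steps alone.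

A modest rise in this assay is therefore expected, of similar size to the step to compound 3, with a real chance of reaching the assay limit. The estimated change is a 2.1-fold higher number from compound 1 to compound 4 (0.33 log units; beyond the scatter). Compound 4 is expected near 95000 nM, with an estimated range from 35000 nM to 220000 nM.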

Compound 4, half-maximal inhibitory concentration: > 100000 nM
Compound 4: only a limit was reported; the forecaster's own chance of this, stated with the estimate: 40%; middle value at least 1.0-fold (0.02 log units) away from the limit.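

In this assay, the bare amino group gives an at least 2.2-fold higher number from compound 1 to compound 4 (0.34 log units; beyond the scatter), so the upward move away from compound 1 persists even with no substituent left on the nitrogen, and all three replacements of 4-chlorophenyl shown now go the same way. Against the ester side chain the result is less informative: the change gives an at least 1.0-fold higher number from compound 3 to compound 4 (0.01 log units; that floor lies within the scatter), which does not separate the amino group from the (ethoxycarbonyl)methyl group. Compound 4, like compound 2, ends at a limit and not at a number, so the step between those two cannot be read and the top of the range carries no order: the limit of > 100000 nM in this assay, at which 2 of the 4 values shown sit.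

Still open, on these data alone, is whether the chlorine or the aromatic ring itself goes with the lower number of compound 1, at 44900 nM, which a plain phenyl or a 4-methoxyphenyl on the nitrogen would help to separate. Also open, as far as these compounds go, is how a carboxylic acid in place of the ethyl ester, or a longer alkyl chain on the nitrogen, would read in this assay.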